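This account rests on a few compounds, and the source may have more. Where it says the series, first, only, none or still open, it means among the compounds named here.

Compound 2 `O[C@H](c1ccccn1)[C@]1(c2cccc(OC(F)(F)F)c2)C[C@H](O)C1` and compound 1 `C[C@]1(O)C[C@](c2cccc(OC(F)(F)F)c2)([C@H](O)c2ccccn2)C1` share one core, while compound 3 `O[C@H](c1ccccn1)[C@]1(c2ccc(C(F)(F)F)cc2)C[C@H](O)C1` is built on a second core; how the two cores differ is not broken down here. In an ADME assay on liver for metabolic stability, with Liver microsome (Homo sapiens) as the target, read by LC-MS, using microsomes, with a stated time of 5 h (on this read-out lower numbers stand for slow clearance and higher numbers for fast clearance), compound 2 gives 150 mL/min/kg, compound 1 gives 117 mL/min/kg, and compound 3 gives 50 mL/min/kg, the lowest of the three numbers, its gaps to compound 1 and compound 2 both beyond the scatter. Between compound 2 and compound 1 the change is methyl in place of hydrogen on a saturated ring carbon, and it gave a 1.3-fold lower number from compound 2 to compound 1 (0.11 log units; within the scatter). Compound 4 `C[C@]1(O)C[C@](c2ccc(C(F)(F)F)cc2)([C@H](O)c2ccccn2)C1` carries the same change on the core of compound 3: methyl in place of hydrogen on a saturated ring carbon. Because compound 3 stands at 50 mL/min/kg and the earlier step was a 1.3-fold lower number from compound 2 to compound 1 (0.11 log units; within the scatter), compound 4 is expected to show a 1.1-fold lower number from compound 3 to compound 4 (0.05 log units; within the scatter) in this assay. Compound 4 is therefore estimated at 45 mL/min/kg, between 25 mL/min/kg and 80 mL/min/kg.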

Compound 4, clearance: 33.3 mL/min/kg
Compound 4: the middle estimate sits 1.4-fold (0.13 log units) above what was measured; low and high end bracket the measured number.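

In this assay methyl in place of hydrogen on a saturated ring carbon gave a 1.5-fold lower number from compound 3 to compound 4 (0.18 log units; within the scatter) and so reads much like the earlier step, with the two cores showing no difference: the same change on two cores in this assay, a 1.3-fold lower number (0.11 log units; within the scatter) from compound 2 to compound 1 and a 1.5-fold lower number (0.18 log units; within the scatter) from compound 3 to compound 4, 1.2-fold (0.07 log units) apart, within the scatter of two such steps. Carried across these two cores, the change therefore behaved consistently, but neither step stands clear of the scatter. The pair shows no firm effect of the methyl on clearance and says nothing about how the change would fare on any further core.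

The compounds shown leave open whether an ethyl group, an amine or a fluorine atom on that ring carbon would give a step beyond the scatter. They also leave open whether the methyl step would hold on a core bearing a nitrile in place of trifluoromethyl.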